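A dimethylphenyl swap near the assay limit

This account rests on a few compounds, and the source may have more. Where it says the series, first, only, none or still open, it means among the compounds named here.

In a functional assay on A549 cells (Homo sapiens) for antiproliferative activity, read by spectrophotometry, with a stated time of 2 days (on this read-out lower numbers stand for stronger inhibition of growth and higher numbers for weaker inhibition of growth), compound 1 (`COc1cc(Nc2ncc(C(F)(F)F)c(N3Cc4cccc(N(C)S(C)(=O)=O)c4C3)n2)c(OC)cc1Cl`) gives 7300 nM. Compound 2 (`Cc1cc(F)ccc1Nc1ncc(C(F)(F)F)c(N2Cc3cccc(N(C)S(C)(=O)=O)c3C2)n1`) gives only a limit, > 30000 nM. Compound 3 (`CN(c1cccc2c1CN(c1nc(Nc3ccc(C(F)(F)F)cc3)ncc1C(F)(F)F)C2)S(C)(=O)=O`) also gives only a limit, > 30000 nM, so it has no exact value. Compound 4 (`Cc1ccc(Nc2ncc(C(F)(F)F)c(N3Cc4cccc(N(C)S(C)(=O)=O)c4C3)n2)c(C)c1`) differs from it as follows: 2,4-dimethylphenyl in place of 4-(trifluoromethyl)phenyl on a nitrogen on an aromatic ring. Two measured steps replace the 4-chloro-2,5-dimethoxyphenyl group of compound 1: an at least 4.1-fold higher number from compound 1 to compound 2 (0.61 log units; beyond the scatter) and an at least 4.1-fold higher number from compound 1 to compound 3 (0.61 log units; beyond the scatter). Both are at least modest and lead to weaker growth inhibition, while a step that the two limits leave unreadable from compound 2 to compound 3 cannot be sized. A similar weak result is therefore expected for the 2,4-dimethylphenyl group, with no step beyond the scatter. The expected step is a number no higher from compound 3 to compound 4 (the limit leaves the size open). The estimate for compound 4 is 30000 nM, within an expected range of 10000 nM to 60000 nM.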

Compound 4, concentration for 50% growth inhibition: 20700 nM
The estimate for compound 4 lay 1.4-fold (0.16 log units) above the measured number, within the range that was stated.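

In this assay, compound 4 gives an exact value at this position on the nitrogen, so the loss from the 4-chloro-2,5-dimethoxyphenyl group can now be sized: a 2.8-fold higher number from compound 1 to compound 4 (0.45 log units; beyond the scatter). The 2,4-dimethylphenyl group still leaves the compound weak, and the swap of methyl for fluoro is no clearer. The steps of an at least 1.4-fold lower number from compound 3 to compound 4 (0.16 log units; that floor lies within the scatter) and an at least 1.4-fold lower number from compound 2 to compound 4 (0.16 log units; that floor lies within the scatter) give only floors, so neither shows a real change: the limit of > 30000 nM in this assay, at which 2 of the 4 values shown sit.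

Which of the chloro and methoxy groups of compound 1 accounts for its lower number stays open. So does how an amine or a carboxylic acid on this phenyl ring would read.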